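A few compounds are considered here, and "the series" means these few. Any claim that something is new, unique, unknown or untested is made for them only; others in the source may bear on it.

Measured compounds:
- compound 1, `COCOc1cc(/C=C/C(=O)OCC(=O)Nc2ccc(Cl)cc2)ccc1OCc1ccccc1`: > 200000 nM
- compound 2, `COc1ccc(/C=C/C(=O)OCC(=O)Nc2ccccc2)cc1OC`: 193000 nM

In a functional assay on HeLa cells (Homo sapiens) for cytotoxicity, read by MTT assay, with a stated time of 72 h (a higher number here means a weaker inhibitor, a lower number a stronger inhibitor), compound 2 gives 193000 nM. This is the only number shown for this assay; the other value is a limit. Compound 1, with `COCOc1cc(/C=C/C(=O)OCC(=O)Nc2ccc(Cl)cc2)ccc1OCc1ccccc1`, reaches only (the limit of > 200000 nM in this assay, at which 1 of the 2 values shown sits), so no number is known for it. Compound 3, with `COc1ccc(/C=C/C(=O)OCC(=O)Nc2ccc(Cl)cc2)cc1OC`, has not yet been measured in this assay. It differs from compound 2 in one place: chloro in place of hydrogen on an aromatic carbon. No step between two measured compounds is shown, so the size of this change cannot be read from the data. Compound 3 is expected to stay close to compound 2, with a step of a 1.0-fold higher number from compound 2 to compound 3 (0.02 log units; within the scatter) that does not go beyond the scatter, and an estimate of 200000 nM is given for compound 3, in a range from 90000 nM to 450000 nM, with a fair chance that this assay again reports only a limit.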

Compound 3, half-maximal inhibitory concentration: 45400 nM
Estimate against measurement, compound 3: 4.4-fold (0.64 log units) above; the measured number lies below the stated range.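

Chloro in place of hydrogen gives a 4.3-fold lower number from compound 2 to compound 3 (0.63 log units; beyond the scatter) in this assay, so this position, para to a large group, responds to the addition of a single chlorine atom, a change whose size could not be read from the earlier compounds. Compound 1 also carries the 4-chlorophenyl group, but its entry is a limit and not a number, so it gives no second reading of this change: the limit of > 200000 nM in this assay, at which 1 of the 3 values shown sits. Nothing shown accounts for the cause of the step.

On these data alone, whether another group at this position, such as fluoro, methoxy or a carboxylic acid, would move the number in the same direction remains open. Also open, as far as these compounds go, is whether chloro would have a similar effect with the other substituents of compound 1 on the core.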